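Trimming the Side Chain to Methyl in a Cytotoxicity Series

The source may hold more compounds than are shown below. What is called first, only, known or untested is meant among the compounds shown, and "the series" means these compounds.

Measured in a functional assay on A549 cells (Homo sapiens) for cytotoxicity, read by MTT assay, with a stated time of 24 h; on this read-out higher numbers stand for weaker inhibition and lower numbers for stronger inhibition:
- compound 1, `CC[C@H](C)[C@@H](NC(=O)Cn1cc(C2=C(c3c[nH]c4ccccc34)C(=O)N(C)C2=O)c2ccccc21)C(=O)OC`, gives > 100000 nM, which is a limit of the assay rather than a number.
- compound 2, `COC(=O)[C@H](NC(=O)Cn1cc(C2=C(c3c[nH]c4ccccc34)C(=O)N(C)C2=O)c2ccccc21)[C@@H](C)O`, gives 25700 nM.

Compound 2 holds the only real number shown in this assay, the other value being a limit. Among the measured compounds shown here, the one measured step, an at least 3.8-fold lower number from compound 1 to compound 2 (0.59 log units; beyond the scatter), runs against the limit (the limit of > 100000 nM in this assay, at which 1 of the 2 values shown sits), so its true size is known only as a lower bound.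

Compound 3, `COC(=O)[C@@H](C)NC(=O)Cn1cc(C2=C(c3c[nH]c4ccccc34)C(=O)N(C)C2=O)c2ccccc21`, differs from compound 2 by methyl in place of 1-hydroxyethyl on a saturated chain carbon bound to an amide-type nitrogen and a carbonyl carbon. For the measured compounds named here, this change removes the hydroxy-bearing chain whose arrival, in the step from compound 1 to compound 2, coincided with the only clear drop in number. Compound 3 is therefore expected to move back toward a higher number in this assay, by a step of about a 2.3-fold higher number from compound 2 to compound 3 (0.37 log units; beyond the scatter), with a fair chance that only a limit is reported. The estimate for compound 3 is 60000 nM, within a range of 20000 nM to 150000 nM.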

Compound 3, half-maximal inhibitory concentration: 30500 nM
Beside the measured number, compound 3's estimate is 2.0-fold (0.29 log units) above it, and the stated range covers the measured number.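

In this assay, the step from hydroxy-bearing chain to methyl reads a 1.2-fold higher number from compound 2 to compound 3 (0.07 log units; within the scatter), so 1-hydroxyethyl and methyl cannot be told apart at this position. The hydroxy group is thus not required for a number in this range, and the contrast that remains is with the sec-butyl of compound 1, as the other new step shows: an at least 3.2-fold lower number from compound 1 to compound 3 (0.51 log units; beyond the scatter). The value of compound 1 is a limit, so the size of that step is known only as a lower bound: the limit of > 100000 nM in this assay, at which 1 of the 3 values shown sits.

What remains open is which feature of the sec-butyl chain goes with the limit, since only three side chains are shown. Whether a plain hydrogen in place of the methyl, a longer straight chain, or a chain ending in an amine or a carboxylic acid would stay in this range is also unanswered.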